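From 1H-indol-6-yl to 4-(dimethylamino)phenyl on a shared core

The source may hold more compounds than are shown below. What is called first, only, known or untested is meant among the compounds shown, and "the series" means these compounds.

Of the compounds shown here, three sharing one core have been measured in a functional assay on A549 cells (Homo sapiens) for inhibition, read by CCK-8 assay, with a stated time of 48 h; a lower number here means a stronger inhibitor, a higher number a weaker inhibitor. Compound 1 `COc1cc(-c2ccnc3cc(-c4ccc(C)c(C)c4)nn23)cc(OC)c1OC` gives 272 nM, compound 2 `COc1cc(-c2ccnc3cc(-c4ccc5c(ccn5C)c4)nn23)cc(OC)c1OC` gives 15 nM, and compound 3 `COc1cc(-c2ccnc3cc(-c4ccc5cc[nH]c5c4)nn23)cc(OC)c1OC` gives 170 nM. Compound 3 therefore sits level with one neighbour and far from the other: the numbers show a 1.6-fold lower number from compound 1 to compound 3 (0.20 log units; within the scatter), but also an 11-fold higher number from compound 2 to compound 3 (1.05 log units; beyond the scatter).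

Compound 4 `COc1cc(-c2ccnc3cc(-c4ccc(N(C)C)cc4)nn23)cc(OC)c1OC` has not been measured yet. It carries 4-(dimethylamino)phenyl in place of 1H-indol-6-yl on an aromatic carbon. Swaps at this same carbon can matter a great deal, as an 18-fold lower number from compound 1 to compound 2 (1.26 log units; beyond the scatter) shows, yet no measured compound carries the entering group. The closest comparison is compound 1, which also has one six-membered aromatic ring of carbon only at this place and gives 272 nM. The expected change in this assay is a 1.4-fold lower number from compound 3 to compound 4 (0.15 log units; within the scatter), so no step beyond the scatter is foreseen. For compound 4 the estimated value is 120 nM, with an expected range from 25 nM to 500 nM.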

Compound 4, half-maximal inhibitory concentration: 1100 nM
For compound 4 the middle estimate is 9.2-fold (0.96 log units) below the measured one; measured number above the stated range.
By their numbers in this assay, from the lowest: compound 2; then compounds 3 and 1 (each within the scatter of the next); then compound 4.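

In this assay, 4-(dimethylamino)phenyl in place of 1H-indol-6-yl gives a 6.5-fold higher number from compound 3 to compound 4 (0.81 log units; beyond the scatter), although both groups have 9 heavy atoms (8 carbon, 1 nitrogen), so matching atom counts do not ensure a matching result at this carbon. The new group also trails 3,4-dimethylphenyl, with a 4.0-fold higher number from compound 1 to compound 4 (0.61 log units; beyond the scatter), and trails 1-methyl-1H-indol-5-yl much further, with a 73-fold higher number from compound 2 to compound 4 (1.87 log units; beyond the scatter), which makes compound 4 the weakest of the four and shows that two groups with one six-membered aromatic ring of carbon only need not sit level. Nothing available here accounts for these differences.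

Still open, on these data alone, is whether the dimethylamino group itself drives the loss, which a 4-aminophenyl or 4-methoxyphenyl group could test. It is also unclear how much of the strength of compound 2 comes from the methyl on the indole nitrogen, a question that 1H-indol-5-yl could address.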